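A few compounds are considered here, and "the series" means these few. Any claim that something is new, unique, unknown or untested is made for them only; others in the source may bear on it.

The measured compounds in a functional assay on HEK293 cells (Homo sapiens) for inhibition, read by MTT assay, with a stated time of 48 h; a higher number here means a weaker inhibitor, a lower number a stronger inhibitor:
Compound 1, `Cc1[nH]c2ccccc2c1C1CC(c2ccncc2)=NO1`, gives > 100000 nM, which is a limit of the assay and not a number.
Compound 2, `COc1ccc2c(C3CC(c4ccncc4)=NO3)c[nH]c2c1`, gives 4160 nM.
Compound 3, `Cc1c(C2CC(c3ccncc3)=NO2)c2ccccc2n1Cc1ccc(Cl)cc1`, gives 2500 nM.

Compound 4, `COc1ccc2c(C3CC(c4ccncc4)=NO3)cn(Cc3ccc(Cl)cc3)c2c1`, has not yet been measured in this assay. It arises from compound 2 by one change: 4-chlorobenzyl in place of hydrogen on an aromatic nitrogen. The same kind of change leads from compound 1 to compound 3: 4-chlorobenzyl in place of hydrogen on an aromatic nitrogen. The surroundings of the place are not identical, since in compound 1 the aromatic nitrogen is next to the ring atom that bears a methyl group, while compound 2 carries no methyl group there. How the core of compound 1 differs from the core of compound 2 is not broken down here.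

In this assay the measured step is an at least 40-fold lower number from compound 1 to compound 3 (1.60 log units; beyond the scatter). Its true size is open-ended because the limit of > 100000 nM in this assay, at which 1 of the 3 values shown sits, sets only a lower bound. Compound 2 and compound 3 lie within the scatter of each other, so no order between them is claimed.

For compound 4 a step of a 2.8-fold lower number from compound 2 to compound 4 (0.44 log units; beyond the scatter) is expected, smaller than the measured one, because compound 2 starts at 4160 nM, which leaves less room before reaching the region where compound 3 sits. The estimate for compound 4 in this assay is 1500 nM, with a likely range from 400 nM to 6000 nM.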

Compound 4, half-maximal inhibitory concentration: 37200 nM
The estimate for compound 4 lay 25-fold (1.39 log units) below the measured number; the measured number lies above the stated range.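

In this assay the change now gives an 8.9-fold higher number from compound 2 to compound 4 (0.95 log units; beyond the scatter), opposite in direction to the earlier step, which shows that the result of placing 4-chlorobenzyl on the aromatic nitrogen does not carry from one core to the other in this series: the same change on two cores in this assay, an at least 40-fold lower number (1.60 log units; beyond the scatter) from compound 1 to compound 3 and an 8.9-fold higher number (0.95 log units; beyond the scatter) from compound 2 to compound 4, at least 350-fold (2.55 log units) apart, beyond the scatter of two such steps

Compound 1 stands at a limit of the assay, > 100000 nM, and not at a number, which leaves the earlier step with only a lower bound: the limit of > 100000 nM in this assay, at which 1 of the 4 values shown sits.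

What the two pairs do not show is which difference between the core of compound 1 and the core of compound 2 goes with the change of direction, and two pairs make no rule for any further core.

The compounds shown leave open how a core carrying both the methyl group and the methoxy group, or neither of them, would respond to the same change. Also open, from the compounds shown here alone, is what would happen on the same aromatic nitrogen with a plain benzyl group, a longer chain ending in an amine, or a chain ending in a carboxylic acid in place of 4-chlorobenzyl.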